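The source may hold more compounds than are shown below. What is called first, only, known or untested is meant among the compounds shown, and "the series" means these compounds.

Measured so far:
- Compound 1 `O=S(=O)(NCC1COC1)c1cccc(-c2ccc3nccc(-c4ccncc4)c3n2)c1`: 19%
- Compound 2 `CS(=O)(=O)Nc1cccc(-c2ccc3nccc(-c4ccncc4)c3n2)c1`: 50%
- Compound 3 `O=S(=O)(NCc1ccccc1)c1cccc(Nc2ccc3nccc(-c4ccncc4)c3n2)c1`: 2%

Not yet measured: compound 4 `Nc1cccc(-c2ccc3nccc(-c4ccncc4)c3n2)c1`

In an ADME assay on microsomes from liver (Mus musculus) for metabolic stability, read by LC-MS, using NADPH, with a stated time of 30 min, tested at 0.1 uM (a higher number here means that more of the compound is left, a lower number that less of the compound is left), compound 2 gives 50%, the highest of the three numbers, and its gaps to compound 1 and compound 3 both lie beyond the scatter. Going to compound 4 puts hydrogen in place of methylsulfonyl on a nitrogen on an aromatic ring, so methanesulfonamido becomes amino: hydrogen in place of methylsulfonyl on a nitrogen on an aromatic ring.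

Among the measured compounds shown here, only one measured step bears on this, and only indirectly: a number 31 percentage points higher from compound 1 to compound 2 (beyond the scatter). This large step brought in the methanesulfonamido group, so changes at this place can clearly move the number. For the measured compounds named here, no measured pair removes the methylsulfonyl, however, and compound 3 differs from compound 2 in more than one place. Going by these compounds, the direction therefore stays open, and no step beyond the scatter is expected, though with wide uncertainty. The expected step is a number 5 percentage points lower from compound 2 to compound 4 (within the scatter). For compound 4 the estimated value is 45%, with an expected range from 20% to 70%.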

Compound 4, percent of the compound remaining: 54%
Beside the measured number, compound 4's estimate is 9 percentage points below it, within the range that was stated.
By their numbers in this assay, from the lowest: compound 3; then compound 1; then compounds 2 and 4 (each within the scatter of the next).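

In this assay, taking the methylsulfonyl off the nitrogen on the aromatic ring changes nothing that can be told apart from the usual scatter (a number 4 percentage points higher from compound 2 to compound 4 (within the scatter)), so this group is not required for the amount of compound left at this level. The second comparison (a number 35 percentage points higher from compound 1 to compound 4 (beyond the scatter)) is large and matches the earlier step from the ((oxetan-3-yl)methyl)sulfamoyl group to methanesulfonamido, which leaves compound 1 apart from both compound 2 and compound 4. Nothing measured here explains why these groups give these numbers.

Still open, going by these compounds, is whether an acetyl or a methyl on this same nitrogen would give a similar number. Compound 3 differs from these compounds in more than one place, so it cannot answer that.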